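The source may report more compounds than this note shows. Statements on the series, on what has been measured and on what is new or still open speak of the compounds shown alone.

The series shares a benzoxaborole core: compound 1 `OB1OCc2ccc(-n3ccc4ccccc43)cc21`, compound 2 `CCNC(=O)c1cccn1-c1ccc2c(c1)B(O)OC2` and compound 3 `O=C(c1ccccc1)c1ccn(-c2ccc3c(c2)B(O)OC3)c1`. In an ADME assay on L929 cells (Mus musculus) for cytotoxicity, read by resazurin assay, with a stated time of 72 h (a lower number here means a stronger inhibitor, a higher number a weaker inhibitor), compound 1 gives only a limit, > 10 ug/mL. In this assay compound 2 likewise gives a limit, > 10 ug/mL. In this assay compound 3 also reaches no number but a limit, > 10 ug/mL, so it stands where the other two stand: all three sit at the limit of > 10 ug/mL in this assay, at which 3 of the 3 values shown sit. Compound 4 `O=C(c1ccc(CO)cc1)c1ccn(-c2ccc3c(c2)B(O)OC3)c1` has not yet been measured; it differs from compound 3 by hydroxymethyl in place of hydrogen on an aromatic carbon. For the measured compounds named here, since no measured step between these compounds exists, the expected step from compound 3 to compound 4 is a step that the limit leaves unreadable from compound 3 to compound 4, none beyond the scatter. Compound 4 is therefore expected to give about 15 ug/mL, within 8 ug/mL to 30 ug/mL.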

Compound 4, half-maximal inhibitory concentration: 9.31 ug/mL
Compound 4: the middle estimate sits 1.6-fold (0.21 log units) above what was measured, and the stated range covers the measured number.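

In this assay compound 4 is the only compound shown that gives a number rather than a limit, 9.31 ug/mL. Hydroxymethyl in place of hydrogen on this aromatic carbon, para to a large group, gives an at least 1.0-fold lower number from compound 3 to compound 4 (0.03 log units; that floor lies within the scatter), so this position accepts the change, but only a floor on the step can be read. On these data alone, the other three compounds remain limits, so the true size of the step stays unknown: the limit of > 10 ug/mL in this assay, at which 3 of the 4 values shown sit.

As far as these compounds go, what a carboxylic acid, an amine or a longer chain in the same place would give in this assay remains open. From the compounds shown here alone, whether hydroxymethyl would give a number on the other compounds also remains open.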